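This account rests on a few compounds, and the source may have more. Where it says the series, first, only, none or still open, it means among the compounds named here.

Compound 2 `CCCCCNC(=O)Nc1ccc(S(=O)(=O)Oc2ccccc2C(C)C)cc1` gives 4600 nM in a functional assay on M21 cells (Homo sapiens) for antiproliferative activity, read by sulforhodamine B assay, with a stated time of 48 h (a higher number here means a weaker inhibitor, a lower number a stronger inhibitor), the lowest of the two numbers recorded so far, though its nearest neighbour, compound 1 `CCCC(=O)Nc1ccc(S(=O)(=O)Oc2ccccc2C(C)C)cc1`, sits close by at 6100 nM. Among the compounds with values here, the only measured step, a 1.3-fold lower number from compound 1 to compound 2 (0.12 log units; within the scatter), replaced pentylamino with propyl on the carbonyl carbon and stayed within the scatter.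

Compound 3 `CC(C)c1ccccc1OS(=O)(=O)c1ccc(NC(=O)NC2CCCC2)cc1` differs from compound 2 by cyclopentyl in place of pentyl on an amide-type nitrogen. Within the data shown here, no measured step exchanges a chain for a ring on that nitrogen, so the one step available bears on it only loosely: it shows that altering the group on the carbonyl side of the shared core left this assay essentially unchanged. On that basis compound 3 is expected to show no step beyond the scatter, no change at the digits printed from compound 2 to compound 3 (within the scatter). The estimate for compound 3 in this assay is therefore 4600 nM, with a range from 1500 nM to 14000 nM.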

Compound 3, half-maximal inhibitory concentration: 6100 nM
Compound 3: middle estimate off by 1.3-fold (0.12 log units), on the low side; measured number inside the range.
By their numbers in this assay, from the lowest: compounds 2, 1 and 3 (each within the scatter of the next).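

In this assay, cyclopentyl in place of pentyl on an amide-type nitrogen gives a 1.3-fold higher number from compound 2 to compound 3 (0.12 log units; within the scatter) and so stays within the scatter: in this pair, a five-membered carbon ring serves as well as an open chain with the same carbon count. Cyclopentylamino in place of propyl on a carbonyl carbon gives no change at the digits printed from compound 1 to compound 3 (within the scatter) as well, so the ring joins the two open chains in a set whose three compounds all lie within the scatter of one another. No available evidence accounts for this flat response.

The compounds shown leave open whether any group at this place can move the number beyond the scatter, as each of the three carries only carbon and hydrogen beyond the amide-type nitrogen or carbonyl. A phenyl ring, an amine or a carboxylic acid on that nitrogen would test how far the flat response extends.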